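Swapping the indolyl group on the double-bonded chain carbon

The compounds below may be only part of what the source reports. "The series", "measured", "known", "first", "only" and "open" are said of these compounds alone.

Measured in a functional assay on DU-145 cells (Homo sapiens) for inhibition, read by trypan blue exclusion, with a stated time of 96 h; a lower number here means a stronger inhibitor of growth, a higher number a weaker inhibitor of growth:
- compound 1 `O=C(/C(=C\c1c[nH]c2ccc(Cl)cc12)SCc1ccc(F)cc1)c1ccc(Br)cc1`: 1000 nM
- compound 2 `Cc1ccc(S/C(=C/c2c[nH]c3ccc(Cl)cc23)C(=O)c2ccc(Br)cc2)cc1`: 1000 nM
- compound 3 `COc1ccc(/C=C(/Sc2ccc(Br)cc2)C(=O)c2ccc(Br)cc2)c(F)c1`: 20000 nM

Compound 1 stands level with compound 2, and together they hold the lowest number of the three. Compound 3 has the highest number of the three.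

The next compound is compound 4 `O=C(/C(=C\c1ccc(O)cc1)SCc1ccc(F)cc1)c1ccc(Br)cc1`, which differs from compound 1 by one change: 4-hydroxyphenyl in place of 5-chloro-1H-indol-3-yl on a double-bonded chain carbon bound to a double-bonded chain carbon. This is 4-hydroxyphenyl in place of 5-chloro-1H-indol-3-yl on a double-bonded chain carbon bound to a double-bonded chain carbon.

Going by the values given here, no measured step covers this place. Among the compounds with values here, the only step available shows no change at the digits printed from compound 1 to compound 2 (within the scatter), with 4-methylphenyl in place of 4-fluorobenzyl on a sulfur, so it says nothing direct about the change here. Within the data shown here, the one indirect hint is compound 3, which lacks the 5-chloro-1H-indol-3-yl group and gives 20000 nM. Compound 3 also differs from compound 1 elsewhere, so it is only a loose guide.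

A weaker inhibitor of growth is therefore expected in this assay, though with wide uncertainty. The expected size of the change is an 8.0-fold higher number from compound 1 to compound 4 (0.90 log units; beyond the scatter). For compound 4 the estimated value is 8000 nM, with an expected range of 1500 nM to 40000 nM.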

Compound 4, concentration for 50% growth inhibition: 10000 nM
Compound 4: the middle estimate sits 1.3-fold (0.10 log units) below what was measured; the measured number falls inside the stated range.
By their numbers in this assay, from the lowest: compounds 1 and 2 (each within the scatter of the next); then compounds 4 and 3 (each within the scatter of the next).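

In this assay, the place on a double-bonded chain carbon bound to a double-bonded chain carbon now has a direct reading, with the rest of compound 1 held fixed: a 10-fold higher number from compound 1 to compound 4 (1.00 log units; beyond the scatter). Going by these compounds alone, the only earlier step, on the group at sulfur, gave no change at the digits printed from compound 1 to compound 2 (within the scatter), so this is the first single change to move the number beyond the scatter, and 5-chloro-1H-indol-3-yl is not interchangeable here with 4-hydroxyphenyl. The change removes the five-membered aromatic ring and the chlorine and brings in the oxygen all at once, and no measurement at hand accounts for the shift.

The compounds shown do not separate the contributions of the chlorine, the five-membered ring and the oxygen; an unchlorinated 1H-indol-3-yl or a 4-aminophenyl at this place would bear on that question. Also open, as far as these compounds go, is whether the same swap gives a step of similar size when 4-methylphenyl replaces 4-fluorobenzyl on the sulfur.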